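The source may report more compounds than this note shows. Statements on the series, on what has been measured and on what is new or still open speak of the compounds shown alone.

Measured in a functional assay on A-431 cells (Homo sapiens) for cytotoxicity, read by MTT assay, with a stated time of 24 h; on this read-out lower numbers stand for stronger inhibition and higher numbers for weaker inhibition:

- Compound 1 `COc1ccc(N(CC(=O)NCCC[Se]c2ccccc2)C(=O)c2ccccc2)cc1`: >= 100000 nM
- Compound 2 `COc1ccc(N(CC(=O)NCCCSc2ccccc2)C(=O)/C=C/c2ccccc2)cc1`: >= 100000 nM
- Compound 3 `COc1ccc(N(CC(=O)NCCCSc2ccccc2)C(=O)C#Cc2ccccc2)cc1`: >= 100000 nM

Each of these entries is a limit of the assay and not a number. Compound 3 stands at >= 100000 nM, which is a limit, so its place in the series can be given only as that limit. Among the compounds with values here, the other two compounds offer no number to rank it against, and the series so far sits at the limit of >= 100000 nM in this assay, at which 3 of the 3 values shown sit.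

The next compound is compound 4 `COc1ccc(N(CC(=O)NCCCSc2ccccc2)C(=O)c2ccccc2)cc1`. It has phenyl in place of 2-phenylethynyl on a carbonyl carbon, so that (2-phenylethynyl)carbonyl becomes benzoyl: phenyl in place of 2-phenylethynyl on a carbonyl carbon.

Within the data shown here, one measured step bears on this place, a step that the two limits leave unreadable from compound 2 to compound 3. It changes the same group on the same carbonyl carbon, but it gives no size to carry over. The expectation therefore rests on the shared limit and not on a measured step size. No number in this assay shows that any change at this carbonyl carbon moves the read-out, so no direction is expected.

The estimated a number no higher from compound 3 to compound 4 (the limit leaves the size open) is expected to stay within the scatter. The most likely report is again only a limit. For compound 4 the expected value is 100000 nM, with an estimated range from 50000 nM to 200000 nM.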

Compound 4, half-maximal inhibitory concentration in the A-431 assay: >= 100000 nM
Compound 4 ended at the assay's limit; the forecaster's own chance of this, stated with the estimate: 85%; the middle value lies on the limit itself.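

In the A-431 assay compound 4 gives >= 100000 nM, which is a limit of the assay and not a number. Compounds 1, 2 and 3 also give only limits in the A-431 assay, so no step among these compounds can be read: the limit of >= 100000 nM in the A-431 assay, at which 4 of the 4 values shown sit.

In a physicochemical assay for lipophilicity, read by HPLC, measured as octanol-water partition (a higher number here means a more lipophilic compound, a lower number a more polar compound), compound 3 gives 3.4 and compound 4 gives 3.1, two values within the scatter of each other.

Going by these compounds, whether a change on the carbonyl carbon or on the saturated chain carbon moves the read-out in the A-431 assay stays open, as does which structure would give a number and not a limit.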